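The source may hold more compounds than are shown below. What is called first, only, known or untested is meant among the compounds shown, and "the series" means these compounds.

Measured so far:
compound 1 `COCC(C(=O)N1CCN(c2cccc(C(F)(F)F)c2)CC1)N1C(=O)CCC1=O` — 50%
compound 2 `CCC(C(=O)N1CCN(c2ccccc2)CC1)N1C(=O)CCC1=O` — 75%
compound 3 `CCC(C(=O)N1CCN(c2cccc(OC)c2)CC1)N1C(=O)CCC1=O` — 0%

In a functional assay on the whole organism (strain Swiss) with Mus musculus as the target, in the maximal electroshock model, with a stated time of 0.5 h, at a dose of 300 mg/kg by the intraperitoneal route (on this read-out higher numbers stand for a stronger effect at the one dose given and lower numbers for a weaker effect), compound 3 gives the lowest of the three numbers: compound 1 gives 50% and compound 2 gives 75%, both well beyond the scatter above it. Compound 4 `CCC(C(=O)N1CCN(c2cccc(C(F)(F)F)c2)CC1)N1C(=O)CCC1=O` is not yet measured; relative to compound 3 the change is trifluoromethyl in place of methoxy on an aromatic carbon. Going by the values given here, one measured step bears on it: a number 75 percentage points lower from compound 2 to compound 3 (beyond the scatter), which shows that methoxy on the aromatic carbon goes with a large loss. Compound 1, carrying trifluoromethyl on the same aromatic carbon but with a different side chain, gives 50%, so trifluoromethyl there is compatible with a mid-range read-out. A large upward step is therefore expected, a number 55 percentage points higher from compound 3 to compound 4 (beyond the scatter), with compound 4 estimated at 55% (range 25% to 85%).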

Compound 4, a percentage reported as activity, at one dose (the size of the read-out at that dose, not a potency): 50%
The estimate for compound 4 lay 5 percentage points above the measured number; measured number inside the range.
By their numbers in this assay, from the lowest: compound 3; then compounds 1 and 4 (each within the scatter of the next); then compound 2.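

In this assay, the outcome at this aromatic carbon depends on the group placed there: a number 50 percentage points higher from compound 3 to compound 4 (beyond the scatter), so the loss seen with methoxy does not extend to every substituent, yet a number 25 percentage points lower from compound 2 to compound 4 (beyond the scatter), so trifluoromethyl still falls short of hydrogen. With trifluoromethyl in place, the chain change is silent: no change at the digits printed from compound 1 to compound 4 (within the scatter). Nothing available explains these steps.

Open, on these data alone, is whether a chlorine atom or an amine on this aromatic carbon would read like hydrogen, trifluoromethyl or methoxy. Also open, as far as these compounds go, is whether the chain change stays silent with methoxy or hydrogen on that carbon.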